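Oxazoline series: phenyl for phenoxy in compound 4

A few compounds are considered here, and "the series" means these few. Any claim that something is new, unique, unknown or untested is made for them only; others in the source may bear on it.

Three compounds of the series have numbers in an assay on isolated protein for inhibition of matrix metalloproteinase-9 (Homo sapiens); a lower number here means a stronger inhibitor, a higher number a weaker inhibitor. Compound 1 `C=C[C@@H]1OC(c2ccc(Br)cc2)=N[C@H]1SC(C)=O` gives 88000 nM, compound 2 `C=C[C@@H]1OC(/C=C/c2ccccc2)=N[C@H]1CO` gives 40000 nM, and compound 3 `C=C[C@@H]1OC(c2ccc(Oc3ccccc3)cc2)=N[C@H]1CO` gives 32000 nM. Compound 3 has the lowest of the three numbers; its nearest neighbour is compound 2, within the scatter, and its furthest is compound 1, beyond the scatter. Compound 4 `C=C[C@@H]1OC(c2ccc(-c3ccccc3)cc2)=N[C@H]1CO` differs from compound 3 in one place: phenyl in place of phenoxy on an aromatic carbon. No step between two measured compounds touches this position, so nothing of the same kind is shown. The group that leaves and the group that enters each carry one six-membered aromatic ring of carbon only; a step of no more than the scatter is expected, in either direction. The estimate for compound 4 in this assay is 30000 nM, within 10000 nM to 90000 nM. The expected step is a 1.1-fold lower number from compound 3 to compound 4 (0.03 log units; within the scatter).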

Compound 4, inhibition constant: 24000 nM
Compound 4: middle estimate off by 1.3-fold (0.10 log units), on the high side, within the range that was stated.
By their numbers in this assay, from the lowest: compounds 4, 3 and 2 (each within the scatter of the next); then compound 1.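

In this assay, phenyl in place of phenoxy on an aromatic carbon gives a 1.3-fold lower number from compound 3 to compound 4 (0.12 log units; within the scatter), so at this position the oxygen of phenoxy can be removed without a step beyond the scatter. Going by these compounds alone, this is the first step read at this position, and the two groups cannot be told apart here. No measurement shown accounts for this step.

Going by these compounds, both groups carry one six-membered aromatic ring of carbon only, so how far the number depends on that ring stays open. An amine, a carboxylic acid or a longer chain at this position could still move the number.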